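Swapping 4-hydroxyphenyl for 2,4-dichlorophenyl: an expected step

The compounds below may be only part of what the source reports. "The series", "measured", "known", "first", "only" and "open" are said of these compounds alone.

Measured so far in a functional assay on Hs-578T cells (Homo sapiens) for inhibition, read by sulforhodamine B assay, with a stated time of 48 h; on this read-out lower numbers stand for stronger inhibition of growth and higher numbers for weaker inhibition of growth:
- compound 1 `O=C(Cc1csc2nc(-c3ccc(Br)cc3)cn12)N/N=C/c1ccccc1O` gives 42700 nM
- compound 2 `O=C(Cc1csc2nc(-c3ccc(Br)cc3)cn12)N/N=C/c1ccc(O)cc1` gives 93300 nM
- compound 3 `COc1cccc(OC)c1/C=N/NC(=O)Cc1csc2nc(-c3ccc(Br)cc3)cn12` gives 45700 nM

Compound 2 has the highest number of the three, which makes it the weakest growth inhibitor here, and its gaps to both neighbours lie beyond the scatter. Compound 4 `O=C(Cc1csc2nc(-c3ccc(Br)cc3)cn12)N/N=C/c1ccc(Cl)cc1Cl`, not yet measured, keeps the shared core and changes one group, on a carbon with a double bond to nitrogen: 2,4-dichlorophenyl in place of 4-hydroxyphenyl on a carbon with a double bond to nitrogen.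

All three measured steps involve this same place. One is a 2.2-fold higher number from compound 1 to compound 2 (0.34 log units; beyond the scatter), and another is a 2.0-fold lower number from compound 2 to compound 3 (0.31 log units; beyond the scatter). Both are modest. The third is a 1.1-fold higher number from compound 1 to compound 3 (0.03 log units; within the scatter), so compound 1 and compound 3 cannot be told apart. Within the data shown here, each of the two groups tried instead of 4-hydroxyphenyl therefore gave a lower number, but that is only two examples, and neither carries chlorine. A modest step downward is the reasonable expectation, of about the size already seen, with no larger change suggested by these data. The expected move is a 1.9-fold lower number from compound 2 to compound 4 (0.27 log units; within the scatter) in this assay. For compound 4 the estimated value is 50000 nM, with an expected range from 20000 nM to 100000 nM.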

Compound 4, concentration for total growth inhibition: 89100 nM
For compound 4 the middle estimate is 1.8-fold (0.25 log units) below the measured one; the range from low to high includes it.
By their numbers in this assay, from the lowest: compounds 1, 3, 4 and 2 (each within the scatter of the next, the first and the last beyond it).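

In this assay, putting 2,4-dichlorophenyl in place of 4-hydroxyphenyl on the carbon with a double bond to nitrogen gives a 1.0-fold lower number from compound 2 to compound 4 (0.02 log units; within the scatter), so the two groups cannot be told apart, even though the hydrogen-bond donor and acceptor counted on 4-hydroxyphenyl are absent from 2,4-dichlorophenyl. This shows that replacing 4-hydroxyphenyl does not always give a clearly lower number at this position, and that a hydroxyl group does not sort these compounds: the same 2,4-dichlorophenyl gives a 2.1-fold higher number from compound 1 to compound 4 (0.32 log units; beyond the scatter), a modest step from one hydroxyphenyl compound, while it cannot be separated from the other. Compound 4 also stays close to the compound without a hydroxyl group, with a 1.9-fold higher number from compound 3 to compound 4 (0.29 log units; within the scatter), and nothing available explains how these groups compare.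

The compounds shown leave open whether a phenyl ring carrying a single chlorine would match 2,4-dichlorophenyl. They also leave open whether an amine or a carboxylic acid on this ring would move the number further than any of these groups has.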